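Removing the Methyl from the Methoxy Group of Compound 2

The source may report more compounds than this note shows. Statements on the series, on what has been measured and on what is new or still open speak of the compounds shown alone.

Three compounds share one core and differ in two places. Compound 1 `O=C(Nc1cccc(-n2cc(-c3ccncc3)c(-c3ccc(Cl)c(O)c3)n2)c1)Nc1cccc(C(F)(F)F)c1` gives 2230 nM in a functional assay on HOP-92 cells (Homo sapiens) for inhibition, read by sulforhodamine B assay, with a stated time of 48 h; on this read-out lower numbers stand for stronger inhibition of growth and higher numbers for weaker inhibition of growth. Compound 3 `COc1cc(-c2nn(-c3cccc(NC(=O)Nc4cccc(C(F)(F)F)c4)c3)cc2-c2ccncc2)ccc1Cl` gives 1770 nM, and compound 2 `COc1cc(-c2nn(-c3cccc(NC(=O)Nc4cc(C(F)(F)F)cc(C(F)(F)F)c4)c3)cc2-c2ccncc2)ccc1Cl` gives 1150 nM, the smallest of the three numbers, though neither gap to the other two exceeds the usual scatter. Compound 4 `O=C(Nc1cccc(-n2cc(-c3ccncc3)c(-c3ccc(Cl)c(O)c3)n2)c1)Nc1cc(C(F)(F)F)cc(C(F)(F)F)c1` is compound 2 with hydrogen in place of methyl on an oxygen on an aromatic ring. The reverse of this change has been measured once: a 1.3-fold lower number from compound 1 to compound 3 (0.10 log units; within the scatter), a shift that stays within the scatter. Going the other way, compound 4 is therefore expected to give a slightly higher number than compound 2, a 1.3-fold higher number from compound 2 to compound 4 (0.12 log units; within the scatter), again within the scatter. The estimate for compound 4 in this assay is 1500 nM, with a range from 700 nM to 3300 nM.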

Compound 4, concentration for total growth inhibition: 1750 nM
Compound 4: middle estimate off by 1.2-fold (0.07 log units), on the low side; the measured number falls inside the stated range.
By their numbers in this assay, from the lowest: compounds 2, 4, 3 and 1 (each within the scatter of the next).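

Methoxy to hydroxy gives a 1.5-fold higher number from compound 2 to compound 4 (0.18 log units; within the scatter), so this change can now be read on two cores, and the two readings agree: the same change on two cores in this assay, a 1.3-fold lower number (0.10 log units; within the scatter) from compound 1 to compound 3 and a 1.5-fold lower number (0.18 log units; within the scatter) from compound 4 to compound 2, 1.2-fold (0.08 log units) apart, within the scatter of two such steps

Trifluoromethyl in place of hydrogen on an aromatic carbon gives a 1.3-fold lower number from compound 1 to compound 4 (0.11 log units; within the scatter), which likewise matches the same change on the other core: the same change on two cores in this assay, a 1.5-fold higher number (0.19 log units; within the scatter) from compound 2 to compound 3 and a 1.3-fold higher number (0.11 log units; within the scatter) from compound 4 to compound 1, 1.2-fold (0.08 log units) apart, within the scatter of two such steps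

Every step among these compounds stays within the scatter, so neither change measurably moves growth inhibition here.

Still open, on these data alone, is whether any group at this position would shift the number beyond the scatter, such as an amine or a longer chain like ethoxy in place of methoxy.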